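Swapping Butyl for Cyclopropyl on the Shared Core

The compounds below may be only part of what the source reports. "The series", "measured", "known", "first", "only" and "open" are said of these compounds alone.

Measured in a functional assay, with a stated time of 30 min; on this read-out higher numbers stand for an effect only at larger amounts of compound and lower numbers for an effect already at smaller amounts:
Compound 1 `CCC/C(C)=N\Nc1nc(-c2cccc([N+](=O)[O-])c2)cs1`: 550000 nM
Compound 2 `CCCC/C(C)=N\Nc1nc(-c2cccc([N+](=O)[O-])c2)cs1`: 520000 nM

In this assay compound 2 gives 520000 nM, which cannot be told apart from the value of compound 1, as the two lie within the scatter of each other. The next structure, compound 3 `C/C(=N/Nc1nc(-c2cccc([N+](=O)[O-])c2)cs1)C1CC1`, keeps the shared core and carries cyclopropyl in place of butyl on a carbon with a double bond to nitrogen.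

Within the data shown here, only one measured step bears on this change: a 1.1-fold lower number from compound 1 to compound 2 (0.02 log units; within the scatter). That step adds a methyl in place of hydrogen on a saturated chain carbon, and it stays within the scatter. It shows that this one change to the chain left the read-out where it was. Among the measured compounds shown here, no measured compound carries a ring at this place, however, so the data offer only weak guidance and the range must stay wide. No shift beyond the scatter is expected in this assay, in either direction. The expected step is a 1.1-fold higher number from compound 2 to compound 3 (0.02 log units; within the scatter). For compound 3 the estimated value is 550000 nM, with an expected range from 220000 nM to 1200000 nM.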

Compound 3, half-maximal effective concentration: 530000 nM
Estimate against measurement, compound 3: 1.0-fold (0.02 log units) above; measured number inside the range.
By their numbers in this assay, from the lowest: compounds 2, 3 and 1 (each within the scatter of the next).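

Among these compounds, compound 3 is the first of the series to carry a ring on the carbon with a double bond to nitrogen, where the earlier compounds carry only open chains. In this assay, cyclopropyl in place of butyl gives a 1.0-fold higher number from compound 2 to compound 3 (0.01 log units; within the scatter), and cyclopropyl in place of propyl gives a 1.0-fold lower number from compound 1 to compound 3 (0.02 log units; within the scatter), so both steps stay within the scatter and this read-out does not separate the one three-membered non-aromatic ring from either chain at this position. No supporting information is available that would account for this result.

Since all three compounds lie within the scatter of each other, the shown changes do not establish whether any substituent at this position can move the read-out, and the step from chain to ring is represented by cyclopropyl alone. On these data alone, it remains open how a larger ring such as cyclohexyl or phenyl, a longer chain, an amine or a carboxylic acid on this carbon would behave in this assay, and whether any of them would give a step beyond the scatter.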